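A few compounds are considered here, and "the series" means these few. Any claim that something is new, unique, unknown or untested is made for them only; others in the source may bear on it.

Measured in a functional assay on HeLa cells (Homo sapiens) for inhibition, read by MTT assay, with a stated time of 72 h; on this read-out lower numbers stand for stronger inhibition and higher numbers for weaker inhibition:
- compound 1 `COc1cc(NC(=O)/C=C/c2cccc(OCc3ccccc3)c2)cc(OC)c1OC`: 2200 nM
- compound 2 `C=C(Br)C(=O)Nc1cccc(/C=C/C(=O)Nc2ccc(F)cc2)c1`: 16800 nM
- compound 3 `C=C(Br)C(=O)Nc1cccc(/C=C/C(=O)Nc2ccc(C)cc2)c1`: 1500 nM

Of these three, compound 2 has the highest number, at 16800 nM, so it is the least inhibitory on the values shown. Compound 4 `C=C(Br)C(=O)Nc1cccc(/C=C/C(=O)Nc2ccc(SC(F)(F)F)cc2)c1` has not yet been measured. It carries (trifluoromethyl)sulfanyl in place of fluoro on an aromatic carbon of compound 2: (trifluoromethyl)sulfanyl in place of fluoro on an aromatic carbon.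

For the measured compounds named here, only one measured step bears on this change. Methyl in place of fluoro at the same place gave an 11-fold lower number from compound 2 to compound 3 (1.05 log units; beyond the scatter), a large step beyond the scatter. Compound 1 differs from compound 2 in more than one place, so it offers no direct comparison. Going by the values given here, no measured compound carries the (trifluoromethyl)sulfanyl group, and a single step is thin evidence. A lower number is therefore expected, but probably by somewhat less than the methyl step, and with wide uncertainty. The expected step is a 4.8-fold lower number from compound 2 to compound 4 (0.68 log units; beyond the scatter). For compound 4 the estimate is 3500 nM, within an expected range of 900 nM to 13000 nM.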

Compound 4, half-maximal inhibitory concentration: 19000 nM
Compound 4: middle estimate off by 5.4-fold (0.73 log units), on the low side, outside the stated range (above it).
By their numbers in this assay, from the lowest: compounds 3 and 1 (each within the scatter of the next); then compounds 2 and 4 (each within the scatter of the next).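

In this assay, (trifluoromethyl)sulfanyl in place of fluoro gives a 1.1-fold higher number from compound 2 to compound 4 (0.05 log units; within the scatter), so these two groups cannot be told apart at this place on the ring, and the larger group does not repeat the gain seen with methyl. Set against methyl, the same group gives a 13-fold higher number from compound 3 to compound 4 (1.10 log units; beyond the scatter), which leaves methyl as the only one of the three groups here linked to the lower number, while fluoro and (trifluoromethyl)sulfanyl sit together despite their different heavy-atom counts. Nothing measured here explains why this position responds in this way.

On these data alone, it remains open whether ethyl, methoxy or an amine at the same place would match methyl or fall back towards fluoro. Also open, as far as these compounds go, is whether this order of groups would hold on the core of compound 1.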